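Diaryl ether series: ring position of the trifluoromethoxy group

The compounds below may be only part of what the source reports. "The series", "measured", "known", "first", "only" and "open" are said of these compounds alone.

Three compounds share one core and are compared in an assay on membranes from brain for binding affinity to Lysophosphatidylserine lipase ABHD12 (Mus musculus), read by fluorescence, with a stated time of 20 min; on this read-out lower numbers stand for stronger inhibition and higher numbers for weaker inhibition. Compound 1 `FC(F)(F)Oc1ccc(Oc2ccnc(N3CCC(NC(=S)Nc4cccnc4)CC3)c2Cl)c(Cl)c1` gives 11 nM in this assay. Compound 2 `FC(F)(F)Oc1ccc(Oc2ccnc(N3CCC(NC(=S)Nc4cccnc4)CC3)c2C(F)(F)F)cc1`, which carries a trifluoromethyl group on the core in place of chlorine, gives 2800 nM. Compound 3 `FC(F)(F)Oc1cccc(Oc2ccnc(N3CCC(NC(=S)Nc4cccnc4)CC3)c2Cl)c1` gives 89 nM in this assay and so stands second highest of the three numbers, nearest to compound 1 and furthest from compound 2.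

For the measured compounds named here, the one single-point step measured so far is an 8.1-fold higher number from compound 1 to compound 3 (0.91 log units; beyond the scatter); it removes a chlorine from the outer ring and moves the trifluoromethoxy group at the same time, so it does not isolate either change.

Compound 4 `FC(F)(F)Oc1ccc(Oc2ccnc(N3CCC(NC(=S)Nc4cccnc4)CC3)c2Cl)cc1` is not yet measured. Relative to compound 3 the change is 4-(trifluoromethoxy)phenyl in place of 3-(trifluoromethoxy)phenyl on an oxygen on an aromatic ring. Going by the values given here, no measured step covers this move of the group alone. Compound 1, which also carries the trifluoromethoxy group in the 4-position of that ring, sits at 11 nM, and, with the same outer ring as compound 4 but a different core, compound 2 sits at 2800 nM; neither pair is a single-point comparison.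

For compound 4 the expected step is a 3.0-fold lower number from compound 3 to compound 4 (0.47 log units; beyond the scatter), toward a lower number, and compound 4 is estimated at 30 nM with a range of 8 nM to 120 nM.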

Compound 4, half-maximal inhibitory concentration: 25 nM
The estimate for compound 4 lay 1.2-fold (0.08 log units) above the measured number; the range from low to high includes it.
By their numbers in this assay, from the lowest: compound 1; then compound 4; then compound 3; then compound 2.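

In this assay the move of the group is now isolated: a 3.6-fold lower number from compound 3 to compound 4 (0.55 log units; beyond the scatter) with 4-(trifluoromethoxy)phenyl in place of 3-(trifluoromethoxy)phenyl on an oxygen on an aromatic ring, so the place of the group on that ring matters on its own while the atom counts stay the same. Compound 4 also separates out the chlorine that the earlier step from compound 1 to compound 3 changed together with that move, since a 2.3-fold higher number from compound 1 to compound 4 (0.36 log units; beyond the scatter) with hydrogen in place of chloro on an aromatic carbon, which is likewise beyond the scatter. For the compounds shown here, on the core itself, a 110-fold lower number from compound 2 to compound 4 (2.05 log units; beyond the scatter) with chloro in place of trifluoromethyl on an aromatic carbon, the first single-place reading of that substituent and the largest step. Nothing at hand explains the size of any of these steps.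

Open, from the compounds shown here alone, is whether a smaller or different group on that core carbon, such as methyl or a nitrile, would fall nearer to chloro or to trifluoromethyl. Also open, going by these compounds, is whether a difluoromethoxy group in place of trifluoromethoxy would keep the difference between the two ring places.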